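Removing the methoxy group from compound 1

A few compounds are considered here, and "the series" means these few. Any claim that something is new, unique, unknown or untested is made for them only; others in the source may bear on it.

Compounds measured so far:
compound 1 `COc1ccccc1C(=O)CSc1nc2ccccc2[nH]1` gives 36100 nM
compound 2 `COc1ccc(C(=O)CSc2nc3ccccc3[nH]2)cc1OC` gives 19100 nM
compound 3 `COc1ccc(C(=O)CSc2nc3ccccc3[nH]2)cc1O` gives 33100 nM

These three were all tested in a functional assay on HT-29 cells (Homo sapiens) for inhibition, read by WST assay, with a stated time of 48 h; on this read-out higher numbers stand for weaker inhibition and lower numbers for stronger inhibition. Compound 1 has the highest of the three numbers, but its gaps to compound 2 and compound 3 both fall within the scatter, so the three cannot be ranked.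

Compound 4 `O=C(CSc1nc2ccccc2[nH]1)c1ccccc1` is not yet measured. It arises from compound 1 by hydrogen in place of methoxy on an aromatic carbon. Within the data shown here, the only measured step that touches a change at an oxygen on the ring is the one a 1.7-fold higher number from compound 2 to compound 3 (0.24 log units; within the scatter), and it stayed within the scatter. Among the measured compounds shown here, no measured step removes a whole methoxy, so the evidence is thin. The expected step in this assay is therefore small, a 1.0-fold lower number from compound 1 to compound 4 (0.00 log units; within the scatter), with no clear direction. Compound 4 is expected to give about 36000 nM, within a range from 14000 nM to 95000 nM.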

Compound 4, half-maximal inhibitory concentration: 38500 nM
Beside the measured number, compound 4's estimate is 1.1-fold (0.03 log units) below it; measured number inside the range.
By their numbers in this assay, from the lowest: compounds 2, 3, 1 and 4 (each within the scatter of the next).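

In this assay, replacing the methoxy on the aromatic carbon ortho to a large group with hydrogen gives a 1.1-fold higher number from compound 1 to compound 4 (0.03 log units; within the scatter), so the whole group can leave this place without a change beyond the scatter. The earlier step altered only the methyl on a ring oxygen, not the whole group. Nothing measured alongside these compounds offers an explanation for this result.

On these data alone, whether an amine or a carboxylic acid at this place would move the number stays open. So does whether removing a methoxy from another ring carbon would behave the same way.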